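The source may hold more compounds than are shown below. What is called first, only, known or untested is meant among the compounds shown, and "the series" means these compounds.

In a functional assay on MCF7 cells (Homo sapiens) for antiproliferative activity, read by MTT assay, with a stated time of 48 h (on this read-out lower numbers stand for stronger inhibition and higher numbers for weaker inhibition), compound 1 (`CCOc1ccc(NC(=O)c2ccc(C(CC)(CC)c3ccc(OCCC(O)(CC)CC)c(C)c3)n2CC)cc1`) reads > 50000 nM as a limit of the assay, not a number. Within the data shown here, compound 2 (`CCOC(=O)CN(C)C(=O)c1ccc(C(CC)(CC)c2ccc(OCCC(O)(CC)CC)c(C)c2)n1CC`) gives 3210 nM and so holds the only true number so far. Compound 3 (`CCOC(=O)C(CC(=O)OC)NC(=O)c1ccc(C(CC)(CC)c2ccc(OCCC(O)(CC)CC)c(C)c2)n1CC`) differs from compound 2 on a carbonyl carbon: a group of 12 heavy atoms (7 carbon, 1 nitrogen, 4 oxygen; no ring) in place of a group of 8 heavy atoms (5 carbon, 1 nitrogen, 2 oxygen; no ring), on a carbonyl carbon. Among the measured compounds shown here, the one measured step at this place, an at least 15-fold lower number from compound 1 to compound 2 (1.19 log units; beyond the scatter), was large, so a wide range is expected, yet that step swapped a different group and gives no direction here. The expected result is a 1.2-fold higher number from compound 2 to compound 3 (0.10 log units; within the scatter) as a step within the scatter. In this assay compound 3 is estimated at 4000 nM, with 1000 nM to 20000 nM as the expected range.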

Compound 3, half-maximal inhibitory concentration: 390 nM
Estimate against measurement, compound 3: 10-fold (1.01 log units) above; the measured number lies below the stated range.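

In this assay, the group on the carbonyl carbon still matters when neither group holds a ring: an 8.2-fold lower number from compound 2 to compound 3 (0.92 log units; beyond the scatter). Set against the ring-bearing group of compound 1, the change is an at least 120-fold lower number from compound 1 to compound 3 (2.10 log units; beyond the scatter). Compound 1 stands at a limit of the assay, not a number: the limit of > 50000 nM in this assay, at which 1 of the 3 values shown sits.

The entering group of compound 3 differs from the group in compound 2 in several features at once, so the shown compounds leave open which feature carries the step. From the compounds shown here alone, whether a carboxylic acid in place of an ester would keep this level of inhibition also remains open.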